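Replacing 4-Hydroxyphenyl with 3,5-Dichlorophenyl

The source may hold more compounds than are shown below. What is called first, only, known or untested is meant among the compounds shown, and "the series" means these compounds.

In an ADME assay on NHDF cells (Homo sapiens) for cytotoxicity, read by MTT assay, with a stated time of 72 h (a higher number here means a weaker inhibitor, a lower number a stronger inhibitor), compound 3 (`COc1cccc(/C=C2\CCC/C(=C\c3ccc(O)cc3)C2=O)c1OC`) gives > 50000 nM, which is a limit of the assay and not a number. The two related compounds gave numbers. Compound 1 (`COc1cccc(/C=C2\CCC/C(=C\c3cccc(Cl)c3)C2=O)c1OC`) gives 21400 nM, and compound 2 (`COc1cccc(/C=C2\CCC/C(=C\c3cccc(O)c3)C2=O)c1OC`) gives 19300 nM. The step between them is a 1.1-fold lower number from compound 1 to compound 2 (0.04 log units; within the scatter), so hydroxy in place of chloro on an aromatic carbon shows no change here.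

Compound 4 (`COc1cccc(/C=C2\CCC/C(=C\c3cc(Cl)cc(Cl)c3)C2=O)c1OC`) has 3,5-dichlorophenyl in place of 4-hydroxyphenyl on a double-bonded chain carbon bound to a double-bonded ring carbon. For the measured compounds named here, two measured steps bear on this change, and both end at the limit: an at least 2.3-fold higher number from compound 1 to compound 3 (0.36 log units; beyond the scatter), and an at least 2.5-fold higher number from compound 2 to compound 3 (0.41 log units; beyond the scatter). Read in reverse, the first of these suggests that the change to compound 4 should bring a lower number, since compound 1 already carries a chloro-substituted phenyl and gives 21400 nM. Going by the values given here, no measured compound carries 3,5-dichlorophenyl, so the effect of the second chloro is unknown, and the range is kept wide. The expected change is an at least 2.9-fold lower number from compound 3 to compound 4 (0.46 log units; beyond the scatter), at least a modest step toward a lower number. For compound 4 the estimated value in this assay is 17000 nM, with an expected range of 7000 nM to 42000 nM.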

Compound 4, half-maximal inhibitory concentration: 21600 nM
Estimate against measurement, compound 4: 1.3-fold (0.10 log units) below; the measured number falls inside the stated range.
By their numbers in this assay, from the lowest: compounds 2, 1 and 4 (each within the scatter of the next). At a limit, above all of these: compound 3.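

In this assay, for the compounds shown here, 3,5-dichlorophenyl in place of 4-hydroxyphenyl, on a double-bonded chain carbon bound to a double-bonded ring carbon, gives an at least 2.3-fold lower number from compound 3 to compound 4 (0.36 log units; beyond the scatter), and this is the first compound carrying two chloro groups to show that the lower number holds with them in place. The second chloro adds nothing that can be seen, since chloro in place of hydrogen on an aromatic carbon gives a 1.0-fold higher number from compound 1 to compound 4 (0.00 log units; within the scatter), and 3,5-dichlorophenyl in place of 3-hydroxyphenyl gives a 1.1-fold higher number from compound 2 to compound 4 (0.05 log units; within the scatter), so 3-chlorophenyl, 3-hydroxyphenyl and 3,5-dichlorophenyl cannot be told apart at this place. Among the four compounds only compound 3, with 4-hydroxyphenyl, stands apart, and its value is a limit and not a number, so the step from it gives a bound and not a size: the limit of > 50000 nM in this assay, at which 1 of the 4 values shown sits.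

The compounds shown leave open whether 4-chlorophenyl or 4-methoxyphenyl at this place would sit with compounds 1, 2 and 4 or at the limit with compound 3. They also leave open whether 3,5-dihydroxyphenyl or an amine on the phenyl ring would keep the number of compound 4 in this assay.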